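The compounds below may be only part of what the source reports. "The series", "measured", "known", "first", "only" and "open" are said of these compounds alone.

Four compounds share a core carrying an amide whose nitrogen is linked through an oxygen to a short chain ending in one or more hydroxyl groups. Compound 1 `O=C(NOC[C@H](O)CO)c1cc2c(c(F)c1Nc1ccc(I)cc1F)OCC2` was tested in an ADME assay on the whole organism (strain Sprague-Dawley) for pharmacokinetics, with Rattus norvegicus as the target, at a dose of 2 mg/kg by the intravenous route (a lower number here means slower removal, a higher number faster removal of the compound), and compound 1 gives 73.6 mL/min/kg, a fairly fast removal. Compound 2 `O=C(NOC[C@H](O)CO)c1cc2ccoc2c(F)c1Nc1ccc(I)cc1F` and compound 3 `O=C(NOCCO)c1cc2ccoc2c(F)c1Nc1ccc(I)cc1F` differ from compound 1 in the core and in the chain; for compound 2 the result in this assay is "not determined" (no result reported), and for compound 3 it is likewise "not determined" (no result reported). So compound 3 stands without a number: nothing measured places it relative to compound 1.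

Compound 4 `O=C(NOC(CO)CO)c1cc2ccoc2c(F)c1Nc1ccc(I)cc1F` has not yet been measured. It differs from compound 3 in one place (hydroxymethyl in place of hydrogen on a saturated chain carbon bound to an oxygen and a saturated chain carbon). Among the compounds with values here, with no number for compound 3, no step can be set against the scatter; the expectation for compound 4 in this assay rests on compound 1 alone, and no shift beyond the scatter is expected from that reference. Compound 4 is therefore expected to show about 60 mL/min/kg, within a range of 25 mL/min/kg to 130 mL/min/kg.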

Compound 4, clearance: 3.4 mL/min/kg
Beside the measured number, compound 4's estimate is 18-fold (1.25 log units) above it; measured number outside the range, below it.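

Within the data shown here, compound 3 has no number in this assay, so no step to compound 4, at 3.4 mL/min/kg, can be read. The compounds shown leave open how hydroxymethyl in place of hydrogen on the chain changes clearance. No further data bear on this result.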